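The source may report more compounds than this note shows. Statements on the series, on what has been measured and on what is new or still open speak of the compounds shown alone.

Compound 1 `O=C(O)CCc1ccc(NCc2ccc(Cl)cc2)cc1`: 111% in a functional assay on CHO cells for agonist activity at Free fatty acid receptor 1 (Homo sapiens), read by reporter gene assay; a lower number here means a smaller maximal response, a higher number a larger maximal response. Compound 2 `O=C(O)C1CC1c1ccc(NCc2cccc(Oc3ccccc3)c2)cc1`: 74% in this assay. Compound 3 `O=C(O)CCc1cccc(NCc2cccc(Oc3ccccc3)c2)c1`: 148% in this assay.

Among these three numbers compound 1 stands second highest: compound 2 lies lower than compound 1 by a margin beyond the usual scatter, and compound 3 lies higher than compound 1 by a margin of the same kind. Compound 4 `O=C(O)CCc1ccc(NCc2ccc(-c3ccccc3)cc2)cc1` differs from compound 1 in one place: phenyl in place of chloro on an aromatic carbon. For the measured compounds named here, no pair of measured compounds that differ in a single place is at hand, so the size of this step cannot be read from any measured pair. A step in this assay that stays within the usual scatter, or leans slightly upward, is expected. For compound 4 the estimated value is 115%, with a range from 85% to 145%. The expected step of a number 4 percentage points higher from compound 1 to compound 4 (within the scatter) is small.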

Compound 4, largest response reached (reported as percent of maximum), in percent of the reference or control that the assay uses: 111%
The estimate for compound 4 lay 4 percentage points above the measured number; the measured number falls inside the stated range.
By their numbers in this assay, from the lowest: compound 2; then compounds 1 and 4 (each within the scatter of the next); then compound 3.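

In this assay, for the compounds shown here, phenyl in place of chloro gives no change at the digits printed from compound 1 to compound 4 (within the scatter), the first step in this set that can be read across a single place. At this aromatic carbon, a six-membered aromatic ring of six heavy atoms can therefore replace a single chlorine atom with the maximal response staying within the scatter. Nothing measured here explains this outcome. On these data alone, it remains open how a methoxy group, an amine or a nitrile at this same carbon would fare. As far as these compounds go, whether phenyl in place of chloro would give a similar step on a different core also remains open.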